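Methylating the amide nitrogen of compound 1

A few compounds are considered here, and "the series" means these few. Any claim that something is new, unique, unknown or untested is made for them only; others in the source may bear on it.

Compound 1 `Cc1cc(/C=C/C#N)cc(C)c1Oc1cc(Nc2ccc(C#N)cc2)c(N)cc1C(N)=O` gives 0.583 h in an in vitro ADME assay on microsomes from liver (Homo sapiens) for metabolic stability, tested at 1 uM (on this read-out higher numbers stand for a longer-lived compound and lower numbers for a shorter-lived compound), the lowest of the two numbers measured, while compound 2 `Cc1cc(CCC#N)cc(C)c1Oc1cc(Nc2ccc(C#N)cc2)c(N)cc1C(N)=O` gives 0.7 h; the step of a 1.2-fold higher number from compound 1 to compound 2 (0.08 log units; within the scatter) lies within the scatter. Compound 3 `CNC(=O)c1cc(N)c(Nc2ccc(C#N)cc2)cc1Oc1c(C)cc(/C=C/C#N)cc1C` differs from compound 1 by methyl in place of hydrogen on an amide-type nitrogen. Within the data shown here, no measured step touches the carbamoyl group: the only known step, 2-cyanoethyl for 2-cyanoethenyl, stayed within the scatter and does not bear on this change. Lacking any guide, no step beyond the scatter is expected, so compound 3 is estimated at 0.55 h in this assay, range 0.25 h to 1.2 h. That expectation corresponds to a 1.1-fold lower number from compound 1 to compound 3 (0.03 log units; within the scatter).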

Compound 3, half-life: 0.747 h
Compound 3: middle estimate off by 1.4-fold (0.13 log units), on the low side, within the range that was stated.
By their numbers in this assay, from the lowest: compounds 1, 2 and 3 (each within the scatter of the next).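

Methyl in place of hydrogen on an amide-type nitrogen is the first change shown at the carbamoyl group, and in this assay it gives a 1.3-fold higher number from compound 1 to compound 3 (0.11 log units; within the scatter). On this read-out, methylcarbamoyl can therefore stand in place of carbamoyl on the core of compound 1 without a step beyond the scatter. No available measurement gives a reason for this result.

Still open, on these data alone, is whether an ethyl group on this nitrogen, or a carboxylic acid in place of the carbamoyl group, would stay within the scatter. Also open, as far as these compounds go, is whether the same methyl change would do so on compound 2.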